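The source may hold more compounds than are shown below. What is called first, only, known or untested is meant among the compounds shown, and "the series" means these compounds.

Of the compounds shown here, three have been measured in a toxicity assay on Huh-7.5 cells (Homo sapiens) for inhibition, read by MTT assay, with a stated time of 96 h; a lower number here means that less compound is tolerated, a higher number that more compound is tolerated. Compound 1 `CN1CCN(Cc2ccc(NC(=O)c3ccc(OCCCCl)c([N+](=O)[O-])c3)cc2C#N)CC1` gives 15500 nM, the lowest of the three numbers, so among them it is the compound the cells tolerate least. Compound 2 `COc1ccc(NC(=O)c2ccc(OCCCN(C)C)c([N+](=O)[O-])c2)cc1` gives 127000 nM and compound 3 `CCC(=O)Nc1cc(C(=O)Nc2ccc(OC)cc2)ccc1OCCCCl` gives 158000 nM; both gaps to compound 1 lie beyond the usual scatter of repeated measurements. Compound 4 `CN1CCN(Cc2ccc(NC(=O)c3ccc(OCCCCl)c([N+](=O)[O-])c3)cc2C(F)(F)F)CC1` has not yet been tested in this assay. It differs from compound 1 in one place: trifluoromethyl in place of cyano on an aromatic carbon. For the measured compounds named here, no measured pair shows this change, so a small shift at most is expected, probably toward a lower number. The estimate for compound 4 in this assay is 12000 nM, ranging from 5000 nM to 30000 nM, an expected step of a 1.3-fold lower number from compound 1 to compound 4 (0.11 log units; within the scatter).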

Compound 4, half-maximal cytotoxic concentration: 6800 nM
Compound 4: the middle estimate sits 1.8-fold (0.25 log units) above what was measured; low and high end bracket the measured number.
By their numbers in this assay, from the lowest: compound 4; then compound 1; then compounds 2 and 3 (each within the scatter of the next).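

In this assay, the position ortho to the (4-methylpiperazin-1-yl)methyl group responds to the exchange of cyano for trifluoromethyl, with a 2.3-fold lower number from compound 1 to compound 4 (0.36 log units; beyond the scatter). For the compounds shown here, this is a modest step, but it is the first comparison here between compounds that differ in one place, and it shows that the cells tolerate less of the trifluoromethyl compound. Nothing available explains the shift.

Still open, from the compounds shown here alone, is how a methyl group, a chlorine atom, an amine or a carboxylic acid at this position would compare. Going by these compounds, it is also open whether the same exchange would give a similar step elsewhere on this ring.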